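This account rests on a few compounds, and the source may have more. Where it says the series, first, only, none or still open, it means among the compounds named here.

Three analogues built on one shared core have been measured so far. In a functional assay on HCC1937 cells (Homo sapiens) for antiproliferative activity, read by CCK-8 assay, with a stated time of 72 h (on this read-out lower numbers stand for stronger inhibition and higher numbers for weaker inhibition), compound 1 `Cc1ccc(C(=O)Nc2cccc(-c3oc4cc(-c5ccc(F)cc5)ccc4c(=O)c3O)c2)cc1` gives 7110 nM. In this assay compound 2 `O=C(Nc1cccc(-c2oc3cc(-c4ccc(F)cc4)ccc3c(=O)c2O)c1)c1ccc(F)cc1F` gives 6980 nM, and compound 3 `Cc1ccccc1C(=O)Nc1cccc(-c2oc3cc(-c4ccc(F)cc4)ccc3c(=O)c2O)c1` gives 9900 nM. Compound 3 holds the highest of the three numbers, yet its gaps to the others, a 1.4-fold higher number from compound 1 to compound 3 (0.14 log units; within the scatter) and a 1.4-fold higher number from compound 2 to compound 3 (0.15 log units; within the scatter), both sit within the scatter, as does a 1.0-fold lower number from compound 1 to compound 2 (0.01 log units; within the scatter). Compound 4 `Cc1cccc(C(=O)Nc2cccc(-c3oc4cc(-c5ccc(F)cc5)ccc4c(=O)c3O)c2)c1` differs from compound 3 by 3-methylphenyl in place of 2-methylphenyl on a carbonyl carbon. The step that bears most on this is a 1.4-fold higher number from compound 1 to compound 3 (0.14 log units; within the scatter), which also moved a methyl on that ring and stayed within the scatter. The step is therefore expected to be a 1.3-fold lower number from compound 3 to compound 4 (0.12 log units; within the scatter). Compound 4 is expected to give about 7500 nM, within a range from 4000 nM to 14000 nM.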

Compound 4, half-maximal inhibitory concentration: 8030 nM
Beside the measured number, compound 4's estimate is 1.1-fold (0.03 log units) below it; measured number inside the range.
By their numbers in this assay, from the lowest: compounds 2, 1, 4 and 3 (each within the scatter of the next).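

All three methyl placements on the ring at this carbonyl carbon can now be compared in this assay, and moving the methyl does not separate them (a 1.2-fold lower number from compound 3 to compound 4 (0.09 log units; within the scatter); a 1.1-fold higher number from compound 1 to compound 4 (0.05 log units; within the scatter)). The 3-methylphenyl group also cannot be told apart from the 2,4-difluorophenyl group (a 1.2-fold higher number from compound 2 to compound 4 (0.06 log units; within the scatter)). No supporting measurement bears on why these numbers lie so close. Still open, going by these compounds, is whether an amine or a carboxylic acid on this ring, or a longer chain in its place, would give a number beyond the scatter.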